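The source may hold more compounds than are shown below. What is called first, only, known or untested is meant among the compounds shown, and "the series" means these compounds.

Values in a functional assay on PC-3 cells (Homo sapiens) for antiproliferative activity, read by MTT assay, with a stated time of 24 h (a higher number here means a weaker inhibitor, a lower number a stronger inhibitor), for the three measured compounds:

Compound 1 `CCN(CC)CCNC(=O)c1ccc(C(CC)(CC)c2ccc(OCS(=O)(=O)c3ccccc3)c(C)c2)n1CC` gives 7130 nM
Compound 2 `CCn1c(C(=O)N[C@H](CO)C(C)C)ccc1C(CC)(CC)c1ccc(OCS(=O)(=O)c2ccccc2)c(C)c1` gives 7300 nM
Compound 3 `CCn1c(C(=O)N[C@@H](CO)CCCO)ccc1C(CC)(CC)c1ccc(OCS(=O)(=O)c2ccccc2)c(C)c1` gives 13400 nM

On these numbers compound 3 stands level with the other two, since neither of its steps leaves the scatter. They are a 1.8-fold higher number from compound 2 to compound 3 (0.26 log units; within the scatter) and a 1.9-fold higher number from compound 1 to compound 3 (0.27 log units; within the scatter) in size.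

The next compound is compound 4 `CCn1c(C(=O)N[C@@H](C(=O)O)C(C)C)ccc1C(CC)(CC)c1ccc(OCS(=O)(=O)c2ccccc2)c(C)c1`, which keeps the shared core of compound 3 and alters only the group on the amide-type nitrogen (a group of 7 heavy atoms (5 carbon, 2 oxygen; no ring) in place of a group of 7 heavy atoms (5 carbon, 2 oxygen; no ring), on an amide-type nitrogen). The group that enters is 1-carboxy-2-methylpropyl.

All three measured steps bear on this change, as each one exchanges the group at this same place. The third of them is a 1.0-fold higher number from compound 1 to compound 2 (0.01 log units; within the scatter) and also stays within the scatter. Even the 2-(diethylamino)ethyl group of compound 1, at 7130 nM in this assay, gives way to the other groups without a step beyond the scatter.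

Going by the values given here, none of the measured compounds carries a carboxy group, however, so the range must stay wide. No step beyond the scatter is therefore expected in this assay, in either direction. The estimated change is a 1.2-fold lower number from compound 3 to compound 4 (0.09 log units; within the scatter) and no more than that. For compound 4 the estimated value is 11000 nM, with 5000 nM to 30000 nM as the expected range.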

Compound 4, half-maximal inhibitory concentration: 3070 nM
For compound 4 the middle estimate is 3.6-fold (0.55 log units) above the measured one; the whole stated range lies above it.
By their numbers in this assay, from the lowest: compound 4; then compounds 1, 2 and 3 (each within the scatter of the next).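

Up to this point every exchange on the amide-type nitrogen had stayed within the scatter in this assay, so that place seemed to tolerate change without consequence; 1-carboxy-2-methylpropyl is the first group to leave the scatter, with a 4.4-fold lower number from compound 3 to compound 4 (0.64 log units; beyond the scatter), a 2.4-fold lower number from compound 2 to compound 4 (0.38 log units; beyond the scatter) and a 2.3-fold lower number from compound 1 to compound 4 (0.37 log units; beyond the scatter), which makes compound 4 the strongest of the four in this assay. The largest of these steps comes between two groups with the same count of 7 heavy atoms (5 carbon, 2 oxygen), so that count alone does not set the number in this series, and the entering group has 1 hydrogen-bond donor where the leaving group has 2. No measurement among those shown accounts for this gain.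

The structures of compound 2 and compound 4 are drawn with opposite arrangements at their defined stereocentre, so the shown values cannot separate the effect of the carboxylic acid from that of the arrangement. Going by these compounds, whether the lower number stays with a carboxylic acid on a longer chain, or survives when a methyl ester or a primary amide takes the place of the carboxylic acid, remains open.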